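The compounds below may be only part of what the source reports. "The series", "measured", "known", "first", "only" and "open" are said of these compounds alone.

Of the compounds shown here, three have been measured, all built on the same core and differing in the aryl group at one end of the conjugated chain. Compound 1 `COc1cc(/C=C/C(=O)/C=C/c2cc(OC)c(OC)c(OC)c2)ccc1OCc1cn(CCCCCOc2cc(=O)oc3ccccc23)nn1` gives 53% in a functional assay on HCT-116 cells (Homo sapiens) for inhibition, read by sulforhodamine B assay, with a stated time of 48 h, tested at 50 uM; on this read-out lower numbers stand for less inhibition of growth and higher numbers for more inhibition of growth at the one concentration tested. Compound 2 `COc1cc(/C=C/C(=O)/C=C/c2cccc3ccccc23)ccc1OCc1cn(CCCOc2cc(=O)oc3ccccc23)nn1` gives 66% in this assay, and compound 3 `COc1ccc(/C=C/C(=O)/C=C/c2ccc(OCc3cn(CCCOc4cc(=O)oc5ccccc45)nn3)c(OC)c2)cc1OC` gives 67% in this assay. On these numbers compound 1 stands lowest of the three: compound 2 lies beyond the scatter above it, and compound 3 lies further above it, also beyond the scatter. Compound 4 `COc1cccc(/C=C/C(=O)/C=C/c2ccc(OCc3cn(CCCCCOc4cc(=O)oc5ccccc45)nn3)c(OC)c2)c1` has not yet been measured. It differs from compound 1 in one place: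

3-methoxyphenyl in place of 3,4,5-trimethoxyphenyl on a double-bonded chain carbon bound to a double-bonded chain carbon

For the measured compounds named here, only one measured step bears on this change, the exchange of the aryl group at the same place between two measured compounds: a number 1 percentage points higher from compound 2 to compound 3 (within the scatter). That step stayed within the scatter, so the data so far give no sign that swapping the aryl group at this position moves the read-out by much, though a single step is a thin basis. The step from compound 1 to compound 4 is therefore expected to be small, a number 2 percentage points higher from compound 1 to compound 4 (within the scatter), with no clear direction. For compound 4 the estimated value in this assay is 55%, expected to fall between 40% and 70%.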

Compound 4, percent growth inhibition at one concentration: 36%
Beside the measured number, compound 4's estimate is 19 percentage points above it; the measured number lies below the stated range.
By their numbers in this assay, from the lowest: compound 4; then compound 1; then compounds 2 and 3 (each within the scatter of the next).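

The aryl group at this position is less indifferent than the earlier pair suggested. In this assay, for the compounds shown here, 3-methoxyphenyl in place of 3,4,5-trimethoxyphenyl gives a number 17 percentage points lower from compound 1 to compound 4 (beyond the scatter) and so moves growth inhibition beyond the scatter, whereas the only earlier exchange on a double-bonded chain carbon bound to a double-bonded chain carbon, 3,4-dimethoxyphenyl in place of naphthalen-1-yl, gave a number 1 percentage points higher from compound 2 to compound 3 (within the scatter). The outcome at this position therefore depends on which aryl groups are exchanged, and the change here, which takes the group from 12 heavy atoms and 3 hydrogen-bond acceptors to 8 heavy atoms and 1 hydrogen-bond acceptor, has no measured explanation so far.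

With only this one pair, the compounds shown leave open whether the fall tracks the number of methoxy groups or depends on which ones remain, a question that 3,5-dimethoxyphenyl or 4-methoxyphenyl on the core of compound 1 would address. They also leave open how groups of another kind would behave at this position, such as a phenyl ring carrying an amine or a carboxylic acid.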